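Swapping ethoxy for cyclohexylamino on the carbonyl of compound 1

A few compounds are considered here, and "the series" means these few. Any claim that something is new, unique, unknown or untested is made for them only; others in the source may bear on it.

Measured in an ADME assay on HeLa cells (Homo sapiens) for cytotoxicity, read by MTT assay, with a stated time of 24 h; on this read-out higher numbers stand for weaker inhibition and lower numbers for stronger inhibition:
compound 1 `CCOC(=O)N1CCN(C(=S)SC(=S)N(C)C)CC1`: 530000 nM
compound 2 `CN(C)C(=S)SC(=S)N1CCN(c2ncccn2)CC1`: > 5000000 nM, a limit of the assay

Going by the values given here, compound 1 holds the only actual number so far, and the other value is a limit. Compound 3 `CN(C)C(=S)SC(=S)N1CCN(C(=O)NC2CCCCC2)CC1` differs from compound 1 by cyclohexylamino in place of ethoxy on a carbonyl carbon. Among the compounds with values here, the single measured step, an at least 9.4-fold higher number from compound 1 to compound 2 (0.97 log units; beyond the scatter), replaces the whole ethoxycarbonyl with pyrimidin-2-yl. It bears only loosely here, as compound 3 keeps the carbonyl. No step beyond the scatter is therefore expected in this assay. The expected step is a 1.3-fold higher number from compound 1 to compound 3 (0.12 log units; within the scatter). For compound 3 the estimated value is 700000 nM, with an expected range of 150000 nM to 3000000 nM.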

Compound 3, half-maximal inhibitory concentration: > 5000000 nM
Compound 3 was reported as a limit; the forecaster's own chance of this, stated with the estimate: 15%; at least 7.1-fold (0.85 log units) between middle value and limit.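

In this assay, keeping the carbonyl does not keep the read-out: cyclohexylamino in place of ethoxy on a carbonyl carbon gives an at least 9.4-fold higher number from compound 1 to compound 3 (0.97 log units; beyond the scatter). The earlier step replaced the whole ethoxycarbonyl, whereas this one shows that a change on the carbonyl carbon alone is enough for a move beyond the scatter. For compound 3 the value is a limit, so the true size of the step stays unknown, and the series now sits mostly at one ceiling: the limit of > 5000000 nM in this assay, at which 2 of the 3 values shown sit.

The compounds shown leave open whether the cyclohexyl ring or the amino nitrogen carries this step. A methylamino group or a cyclohexyloxy group on the carbonyl carbon would separate the two.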